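This account rests on a few compounds, and the source may have more. Where it says the series, first, only, none or still open, it means among the compounds named here.

In a functional assay (muscle tissue) with Cavia porcellus as the target (on this read-out higher numbers stand for an effect only at larger amounts of compound and lower numbers for an effect already at smaller amounts), two compounds on a shared core have been measured. Compound 1 (`COC(=O)C1=C(C)N=C(C)/C(=C(\O)OC)C1c1cccc(N)c1`) gives 2000 nM and compound 2 (`COC(=O)C1=C(C)N=C(C)/C(=C(\O)OC)C1c1cccc(Br)c1`) gives 1.29 nM as the lower of the two numbers. Compound 3 (`COC(=O)C1=C(C)N=C(C)/C(=C(\O)OC)C1c1cccc([N+](C)(C)C)c1`) has not yet been measured. Compared with compound 2, the change is a group of 4 heavy atoms (3 carbon, 1 nitrogen; no ring) in place of one bromine atom, on an aromatic carbon and the new group stands on an aromatic carbon of a six-membered aromatic ring of carbon only, meta to a large group. Among the measured compounds shown here, no measured compound here carries a group with a net charge +1, so the evidence is indirect.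

For the measured compounds named here, one measured step bears on this change: bromo in place of amino on an aromatic carbon gave a 1600-fold lower number from compound 1 to compound 2 (3.19 log units; beyond the scatter) and that step is large. Compound 1, with its amino group on that same carbon, gives 2000 nM and so a large step to a higher number in this assay is expected on leaving bromo, although a single pair is a thin basis. The expected step is a 2300-fold higher number from compound 2 to compound 3 (3.37 log units; beyond the scatter) by this estimate. For compound 3 the estimate is 3000 nM with an expected range from 200 nM to 40000 nM overall.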

Compound 3, half-maximal effective concentration: 50100 nM
For compound 3 the middle estimate is 17-fold (1.22 log units) below the measured one, and the stated range ends below it.
By their numbers in this assay, from the lowest: compound 2; then compound 1; then compound 3.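

In this assay this position on the aromatic carbon now shows a far wider span than the first pair revealed: placing the group with net charge +1 in place of bromo gives a 39000-fold higher number from compound 2 to compound 3 (4.59 log units; beyond the scatter) and so moves the number sharply upward. The amino group no longer marks the high end at this carbon, for the same group in place of amino still gives a 25-fold higher number from compound 1 to compound 3 (1.40 log units; beyond the scatter) and compound 3 stands highest of the three, with its steps to both others beyond the scatter. No measurement at hand explains why this change carries such a large step.

The change from bromo alters the heavy-atom count and the net charge together, and the three compounds cannot tell these two differences apart. A tert-butyl group, which has carbon in place of the charged nitrogen, or a dimethylamino group on the same aromatic carbon would bear on that question, and the compounds shown also leave open how a carboxylic acid would behave there.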